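Working notes: 2-fluorophenyl in place of 4-bromophenyl

This account rests on a few compounds, and the source may have more. Where it says the series, first, only, none or still open, it means among the compounds named here.

Measured in a functional assay on MCF7 cells (Homo sapiens) for antiproliferative activity, read by MTT assay, with a stated time of 72 h; a higher number here means a weaker inhibitor, a lower number a stronger inhibitor:
- compound 1 `CCCSc1nc(N/N=C(\C)c2ccc(O)cc2)c2nnn(Cc3ccccc3)c2n1`: 21600 nM
- compound 2 `CCCSc1nc(N/N=C/c2ccccc2Cl)c2nnn(Cc3ccccc3)c2n1`: 13800 nM
- compound 3 `CCCSc1nc(N/N=C/c2ccc(Br)cc2)c2nnn(Cc3ccccc3)c2n1`: > 64000 nM (a limit, not a number)

Compound 3 has no number, only (the limit of > 64000 nM in this assay, at which 1 of the 3 values shown sits).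

Compound 4 `CCCSc1nc(N/N=C/c2ccccc2F)c2nnn(Cc3ccccc3)c2n1` carries 2-fluorophenyl in place of 4-bromophenyl on a carbon with a double bond to nitrogen.

Going by the values given here, three measured steps bear on this change. The closest is an at least 4.6-fold higher number from compound 2 to compound 3 (0.66 log units; beyond the scatter), which is the same kind of exchange at the same carbon, and it is itself bounded by the limit. The others are an at least 2.9-fold higher number from compound 1 to compound 3 (0.47 log units; beyond the scatter) and a 1.6-fold lower number from compound 1 to compound 2 (0.19 log units; within the scatter).

Compound 4 has 2-fluorophenyl where compound 2 has 2-chlorophenyl, so compound 4 is expected to fall near compound 2 at 13800 nM. An expected step of an at least 3.5-fold lower number from compound 3 to compound 4 (0.55 log units; beyond the scatter) follows in this assay, toward a lower number. Compound 4 is estimated at 18000 nM, with an expected range from 7000 nM to 50000 nM.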

Compound 4, half-maximal inhibitory concentration: > 64000 nM
Compound 4: no number, only a limit (the forecaster's own chance of this, stated with the estimate: 15%); middle value at least 3.5-fold (0.55 log units) away from the limit.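

In this assay compound 4 gives > 64000 nM, which is a limit and not a number, so a second compound now sits at that limit: the limit of > 64000 nM in this assay, at which 2 of the 4 values shown sit.

Fluoro in place of chloro on an aromatic carbon gives an at least 4.6-fold higher number from compound 2 to compound 4 (0.66 log units; beyond the scatter), so exchanging this one halogen is enough to separate compound 4 from compound 2, and 2-chlorophenyl cannot stand for 2-halophenyl groups in general. Compound 4 also separates from the hydroxylated methyl-bearing compound, with an at least 2.9-fold higher number from compound 1 to compound 4 (0.47 log units; beyond the scatter), while the step between the two limits cannot be read.

On these data alone, how far compound 3 and compound 4 lie beyond the limit, and whether they differ at all, stays open. Also open, as far as these compounds go, is whether a methoxy group or an amine on this aromatic ring would give a measurable value, as the chloro group of compound 2 does.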